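The compounds below may be only part of what the source reports. "The series", "measured", "known", "first", "only" and "open" are said of these compounds alone.

Measured so far in a functional assay on SW480 cells (Homo sapiens) for inhibition, read by MTT assay, with a stated time of 72 h; a higher number here means a weaker inhibitor of growth, a lower number a stronger inhibitor of growth:
Compound 1 `O=C(NCc1ccccc1)c1cc(Br)c(Br)[nH]1`: > 50000 nM, which is a limit of the assay rather than a number.
Compound 2 `O=C(NCc1ccc(Cl)cc1)c1cc(Br)c(Br)[nH]1`: 36000 nM.

Among the measured compounds shown here, compound 2 thus holds the only real number in this assay; the other value is a limit. Compound 3 `O=C(NCc1ccc(Cl)c(Cl)c1)c1cc(Br)c(Br)[nH]1` differs from compound 2 by chloro in place of hydrogen on an aromatic carbon. For the measured compounds named here, the one measured step that bears on this, an at least 1.3-fold lower number from compound 1 to compound 2 (0.14 log units; that floor lies within the scatter), lies within the scatter, and the limit of > 50000 nM in this assay, at which 1 of the 2 values shown sits, caps what it can tell. In this assay no step beyond the scatter is expected, at most a small move to a lower number. Compound 3 is therefore estimated at 25000 nM, between 8000 nM and 60000 nM, an expected step of a 1.4-fold lower number from compound 2 to compound 3 (0.16 log units; within the scatter).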

Compound 3, concentration for 50% growth inhibition: 33000 nM
Compound 3: the middle estimate sits 1.3-fold (0.12 log units) below what was measured; measured number inside the range.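

In this assay, among the compounds shown here, a chloro ortho to a chloro group gives a 1.1-fold lower number from compound 2 to compound 3 (0.04 log units; within the scatter) and this is the first step here read between two real numbers. It shows that compound 2 and compound 3 cannot be told apart, so this second chloro brings no measurable change in growth inhibition. The earlier step rested on a limit of the assay and not on a number: the limit of > 50000 nM in this assay, at which 1 of the 3 values shown sits.

From the compounds shown here alone, whether an amine, a carboxylic acid or a methoxy group at this same position would behave like chloro stays open. So does whether any group here gives a step beyond the scatter.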